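This account rests on a few compounds, and the source may have more. Where it says the series, first, only, none or still open, it means among the compounds named here.

Within the data shown here, compound 2 `COc1ccc(-c2cnc(C(=O)CCCCCCc3ccccc3)o2)cc1` gives 100 nM in an assay (Rattus norvegicus) for inhibition of Fatty-acid amide hydrolase 1 (Homo sapiens) (a lower number here means a stronger inhibitor, a higher number a weaker inhibitor), the highest of the two numbers so far; compound 1 `NC(=O)c1cccc(-c2cnc(C(=O)CCCCCCc3ccccc3)o2)c1` gives 6 nM in this assay, and the only measured step, a 17-fold higher number from compound 1 to compound 2 (1.22 log units; beyond the scatter), changes a different group on the same aromatic carbon. Compound 3 `COc1ccnc(-c2cnc(C(=O)CCCCCCc3ccccc3)o2)c1` differs from compound 2 by 4-methoxypyridin-2-yl in place of 4-methoxyphenyl on an aromatic carbon. Among the measured compounds shown here, no measured step alters a ring atom inside this group, so the step of a 17-fold higher number from compound 1 to compound 2 (1.22 log units; beyond the scatter) bears on the change only loosely. A step within the scatter is therefore expected, no change at the digits printed from compound 2 to compound 3 (within the scatter). Compound 3 is estimated at 100 nM, with a range from 30 nM to 300 nM.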

Compound 3, inhibition constant: 0.8 nM
Estimate against measurement, compound 3: 130-fold (2.10 log units) above; the whole stated range lies above it.
By their numbers in this assay, from the lowest: compound 3; then compound 1; then compound 2.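

In this assay, replacing one ring carbon of the 4-methoxyphenyl group with nitrogen, at this place next to the ring oxygen, has a large effect (a 130-fold lower number from compound 2 to compound 3 (2.10 log units; beyond the scatter)). The change to 4-methoxypyridin-2-yl also surpasses 3-carbamoylphenyl (a 7.5-fold lower number from compound 1 to compound 3 (0.88 log units; beyond the scatter)), so a carbamoyl group is not required for a low number here. Nothing available accounts for either step. Open, from the compounds shown here alone, is whether the gain survives with the ring nitrogen elsewhere, as in a pyridin-3-yl group. Also open, going by these compounds, is whether it persists when a carboxylic acid or a chlorine replaces the methoxy group.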